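Chloro on the phenyl ring of the tetrabromo series

This account rests on a few compounds, and the source may have more. Where it says the series, first, only, none or still open, it means among the compounds named here.

Measured so far:
compound 1 `OC(CCn1nc2c(Br)c(Br)c(Br)c(Br)c2n1)c1cccc(Br)c1` — 54%
compound 2 `OC(CCn1nc2c(Br)c(Br)c(Br)c(Br)c2n1)c1cccc(Cl)c1` — 68%
compound 3 `OC(CCn1nc2c(Br)c(Br)c(Br)c(Br)c2n1)c1ccccc1` — 84%

In a functional assay on CCRF-CEM cells (Homo sapiens) for antiproliferative activity, read by MTT assay, with a stated time of 48 h, tested at 25 uM (on this read-out lower numbers stand for a stronger effect and higher numbers for a weaker effect at the one concentration tested), compound 3 stands highest of the three numbers, that is weakest at the one concentration tested. The nearest is compound 2, a step of a number 16 percentage points higher from compound 2 to compound 3 (beyond the scatter); the furthest is compound 1, a step of a number 30 percentage points higher from compound 1 to compound 3 (beyond the scatter). Both of these steps are beyond the scatter, and so is a number 14 percentage points higher from compound 1 to compound 2 (beyond the scatter).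

Compound 4 `OC(CCn1nc2c(Br)c(Br)c(Br)c(Br)c2n1)c1ccc(Cl)cc1` differs from compound 3 by chloro in place of hydrogen on an aromatic carbon. Among the compounds with values here, the measured step that bears on it most is the exchange of chloro for hydrogen between compound 2 and compound 3, a number 16 percentage points higher from compound 2 to compound 3 (beyond the scatter), which runs the opposite way; no step with chloro at the place described for compound 4 has been measured, so the size carries added doubt. The step from compound 1 to compound 3 shows that removing a halogen from the phenyl ring raised the number in this assay each time. On that basis compound 4 is expected to come in lower than compound 3, by an estimated a number 14 percentage points lower from compound 3 to compound 4 (beyond the scatter), and its value is estimated at 70%, with a range from 52% to 86%.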

Compound 4, a percentage reported as activity, at one concentration (the size of the read-out at that concentration, not a potency): 69%
Beside the measured number, compound 4's estimate is 1 percentage points above it; low and high end bracket the measured number.
By their numbers in this assay, from the lowest: compound 1; then compounds 2 and 4 (each within the scatter of the next); then compound 3.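

In this assay, chloro para to a large group also lowers the number (a number 15 percentage points lower from compound 3 to compound 4 (beyond the scatter)), so the lowering seen with compound 2 is not confined to that compound's chloro placement. With 4-chlorophenyl in place of 3-chlorophenyl, the two chloro compounds cannot be told apart (a number 1 percentage points higher from compound 2 to compound 4 (within the scatter)), while the 3-bromophenyl compound remains separated from the 4-chlorophenyl compound (a number 15 percentage points higher from compound 1 to compound 4 (beyond the scatter)). No measurement shown accounts for these numbers.

The compounds shown leave open whether a methoxy group or an amine on the phenyl ring would lower the number as chloro does, or would leave it near that of the unsubstituted phenyl compound. They also leave open how a longer chain between the core and the phenyl ring would read in this assay at this single concentration.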